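The source may report more compounds than this note shows. Statements on the series, on what has been measured and on what is new or still open speak of the compounds shown alone.

Compound 1 `O=C(NS(=O)(=O)c1ccccc1)n1ccc2cccnc21` gives 19% in a functional assay on MCF7 cells (Homo sapiens) for antiproliferative activity, read by MTT assay, with a stated time of 24 h, tested at 10 uM; a higher number here means more inhibition at the concentration tested (going by the name of the read-out), a lower number less inhibition. Compound 2 `O=C(NS(=O)(=O)c1ccc(Cl)cc1)n1ccc2cccnc21` carries the change chloro in place of hydrogen on an aromatic carbon and in this assay compound 2 gives 33.5%, a step of a number 14.5 percentage points higher from compound 1 to compound 2 (beyond the scatter). Compound 3 `O=C(NS(=O)(=O)c1ccc2ccccc2c1)n1ccc2cccnc21` has another core; the difference between the cores of compound 1 and compound 3 is not broken down here. In this assay compound 3 gives 1.9%, the lowest of the three. Compound 4 `O=C(NS(=O)(=O)c1ccc2ccccc2c1)n1ccc2c(Cl)ccnc21` differs from compound 3 by chloro in place of hydrogen on an aromatic carbon. This is the same kind of change as from compound 1 to compound 2, but the place differs: there the chloro sits on a six-membered aromatic ring of carbon only, para to a large group; here it sits on a six-membered aromatic ring with 1 nitrogen, part of a fused system of two rings, ortho to a fused ring, meta to a fused ring, opposite the ring nitrogen. A step of a number 7.1 percentage points higher from compound 3 to compound 4 (within the scatter) is expected, smaller than the earlier one, which rests only on the step of a number 14.5 percentage points higher from compound 1 to compound 2 (beyond the scatter) and on compound 3 giving 1.9%. For compound 4 the estimate is 9%, between 0% and 25%.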

Compound 4, a percentage reported as inhibition, at one concentration (the size of the read-out at that concentration, not a potency): 28.6%
The estimate for compound 4 lay 19.6 percentage points below the measured number, outside the stated range (above it).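

In this assay, chloro in place of hydrogen on an aromatic carbon gives a number 26.7 percentage points higher from compound 3 to compound 4 (beyond the scatter), and this step and the earlier one point the same way and cannot be told apart in size: the same change on two cores in this assay, a number 14.5 percentage points higher (beyond the scatter) from compound 1 to compound 2 and a number 26.7 percentage points higher (beyond the scatter) from compound 3 to compound 4, 12.2 percentage points apart, within the scatter of two such steps. So, across these two pairs, the direction of the change carries from one core to the other, even though the chloro sits on a different ring in each pair. Two pairs at a single concentration do not show a rule for other cores, nor do they separate the effect of the place from that of the core.

Still open, from the compounds shown here alone, is whether a methoxy group or an amine on the aromatic carbon opposite the ring nitrogen would follow the same direction. Also open, going by these compounds, is how chloro behaves on the other ring of each core.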